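The source may report more compounds than this note shows. Statements on the series, on what has been measured and on what is new or still open speak of the compounds shown alone.

Of the compounds shown here, two sharing a core have so far been tested in a functional assay on CCRF-CEM cells (Homo sapiens) for cytotoxicity, read by MTT assay, with a stated time of 72 h; a lower number here means a stronger inhibitor, a higher number a weaker inhibitor. Compound 1 `Cc1ccc(NN=C(c2nc3ccccc3[nH]2)c2nc3ccccc3[nH]2)cc1` gives 26500 nM in this assay, and compound 2 `Clc1ccc(NN=C(c2nc3ccccc3[nH]2)c2nc3ccccc3[nH]2)cc1` gives 42500 nM. Among the compounds with values here, compound 2 thus holds the higher of the two numbers, yet the only measured step, a 1.6-fold higher number from compound 1 to compound 2 (0.21 log units; within the scatter), is too small to separate the two compounds. Compound 3 `O=[N+]([O-])c1ccc(NN=C(c2nc3ccccc3[nH]2)c2nc3ccccc3[nH]2)cc1` has not yet been measured; it differs from compound 2 by nitro in place of chloro on an aromatic carbon. Within the data shown here, the one step that bears on this change is the earlier swap of one group for another at the same place on the ring, and it moved the number by less than the scatter. No other evidence exists for the nitro group here. A step of similar size in this assay is therefore expected, with no clear direction, so compound 3 is estimated at 40000 nM, between 15000 nM and 110000 nM, meaning a 1.1-fold lower number from compound 2 to compound 3 (0.03 log units; within the scatter).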

Compound 3, half-maximal inhibitory concentration: 58400 nM
Compound 3: the middle estimate sits 1.5-fold (0.16 log units) below what was measured, and the stated range covers the measured number.
By their numbers in this assay, from the lowest: compounds 1, 2 and 3 (each within the scatter of the next, the first and the last beyond it).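

In this assay, nitro in place of chloro, a change that adds heavy atoms and hydrogen-bond acceptors on the aromatic carbon, gives a 1.4-fold higher number from compound 2 to compound 3 (0.14 log units; within the scatter), so this swap does not separate the two compounds. Across the three groups tried at this place, a difference beyond the scatter appears only for nitro in place of methyl, with a 2.2-fold higher number from compound 1 to compound 3 (0.34 log units; beyond the scatter), and that step is modest. No measurement shown here explains either step.

The compounds shown leave open whether an amine, a carboxylic acid or a methoxy group on this carbon would give a number within the same narrow spread. They also leave open whether a change to the shared core, rather than to this group, would move the number further.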